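The compounds below may be only part of what the source reports. "The series", "measured", "known", "first", "only" and "open" are said of these compounds alone.

Measured so far:
- compound 1, `COc1ccc(CN(C(=O)CO)c2cc(OC)c(OC)c(OC)c2)cc1O`: 520 nM
- compound 2, `COc1ccc(CNc2cc(OC)c(OC)c(OC)c2)cc1`: 18400 nM

In a functional assay on HCT-116 cells (Homo sapiens) for inhibition, read by MTT assay, with a stated time of 48 h (a lower number here means a stronger inhibitor, a higher number a weaker inhibitor), compound 1 gives 520 nM, the lower of the two numbers recorded. Among the compounds with values here, compound 2, which carries no acyl group on the nitrogen and lacks the hydroxy on the outer ring, gives 18400 nM; the gap from compound 1 to compound 2 is far beyond the scatter, though no single-point step links the two, so only the values themselves can be read.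

Compound 3, `COc1ccc(CN(C(=O)CBr)c2cc(OC)c(OC)c(OC)c2)cc1O`, is not yet measured. It differs from compound 1 in one place: bromo in place of hydroxy on a saturated chain carbon bound to a carbonyl carbon. Within the data shown here, no step between measured compounds covers this exchange, so the expected size of the step rests on compound 1 alone. A downward step, modest in size and possibly still within the scatter, is expected from compound 1 to compound 3, a 1.7-fold lower number from compound 1 to compound 3 (0.24 log units; within the scatter). Compound 3 is accordingly estimated at 300 nM in this assay, with a range from 80 nM to 1500 nM.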

Compound 3, half-maximal inhibitory concentration: 68 nM
The estimate for compound 3 lay 4.4-fold (0.64 log units) above the measured number, and the stated range ends above it.
By their numbers in this assay, from the lowest: compound 3; then compound 1; then compound 2.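

In this assay, the exchange of hydroxymethyl for bromomethyl gives a 7.6-fold lower number from compound 1 to compound 3 (0.88 log units; beyond the scatter), so the number responds to a change at this saturated chain carbon bound to a carbonyl carbon. Within the data shown here, compound 1 and compound 2 differ in more than one place, so they could not tie any difference in value to a single position; this step is the first reading of that kind. It also shows that the hydroxy, with its hydrogen-bond donor and acceptor, is not required at this place for a value in this range, since compound 3, which has neither on the bromo group, gives 68 nM.

Going by these compounds, whether chloro, iodo, an amine or a longer chain at this carbon would follow bromo or hydroxy remains open. Nothing on hand gives a reason for the size of this step.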